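Swapping the aryl sulfonyl group of compound 2

The source may report more compounds than this note shows. Statements on the series, on what has been measured and on what is new or still open speak of the compounds shown alone.

Compound 1 `COc1cc(-c2nc(-c3ccccc3)[nH]c2-c2ccnc(NCCCNS(=O)(=O)c3ccc(C)cc3)n2)ccc1Cl`: 18600 nM
Compound 2 `O=S(=O)(NCCCNc1nccc(-c2[nH]c(-c3ccccc3)nc2-c2ccc(F)c(O)c2)n1)c1cccc(F)c1`: 7890 nM

In a functional assay on LOX IMVI cells (Homo sapiens) for cytotoxicity, read by MTT assay, with a stated time of 24 h (on this read-out lower numbers stand for stronger inhibition and higher numbers for weaker inhibition), compound 2 holds the lower of the two numbers, at 7890 nM, a gap to compound 1 that lies beyond the scatter. Compound 3 `Cc1ccc(S(=O)(=O)NCCCNc2nccc(-c3[nH]c(-c4ccccc4)nc3-c3ccc(F)c(O)c3)n2)cc1` is not yet measured. It differs from compound 2 in one place: 4-methylphenyl in place of 3-fluorophenyl on a sulfonyl sulfur. Among the measured compounds shown here, compound 1 carries that group too, but it differs from compound 3 elsewhere, so no measured step isolates this change. No change beyond the scatter is therefore expected in this assay. The expected size of the step is a 1.1-fold higher number from compound 2 to compound 3 (0.03 log units; within the scatter). Compound 3 is estimated at 8500 nM, with an expected range of 3500 nM to 20000 nM.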

Compound 3, half-maximal inhibitory concentration: 26300 nM
Beside the measured number, compound 3's estimate is 3.1-fold (0.49 log units) below it, outside the stated range (above it).
By their numbers in this assay, from the lowest: compound 2; then compounds 1 and 3 (each within the scatter of the next).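

In this assay, the group on the sulfonyl sulfur proves to matter: with all else unchanged, 4-methylphenyl in place of 3-fluorophenyl gives a 3.3-fold higher number from compound 2 to compound 3 (0.52 log units; beyond the scatter), a modest loss of activity. With 4-methylphenyl kept, 4-fluoro-3-hydroxyphenyl in place of 4-chloro-3-methoxyphenyl gives a 1.4-fold higher number from compound 1 to compound 3 (0.15 log units; within the scatter), which stays within the scatter. No measurement here explains either result.

As far as these compounds go, it remains open whether the loss follows the departing fluorine or the incoming methyl. A plain phenyl or a methyl group on the sulfonyl sulfur could help separate the two.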